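The source may report more compounds than this note shows. Statements on the series, on what has been measured and on what is new or still open speak of the compounds shown alone.

Compound 2 `CS(=O)(=O)c1ccc(Cl)cc1NCC1=NCCN1` gives 91% in a functional assay for agonist activity at Alpha-1A adrenergic receptor (Homo sapiens) (on this read-out higher numbers stand for larger maximal responses and lower numbers for smaller maximal responses), the top of the two numbers shown so far, though compound 1 `CSc1ccc(F)cc1NCC1=NCCN1` gives 90% in this assay, within the scatter of that. Compound 3 `Cc1ccc(S(C)(=O)=O)c(NCC2=NCCN2)c1` differs from compound 2 by methyl in place of chloro on an aromatic carbon. Among the compounds with values here, no step between measured compounds is available, so the series gives no computed size for such a change. Both measured compounds sit near full maximal response in this assay. The step from compound 2 to compound 3 is expected to be a number 1 percentage points lower from compound 2 to compound 3 (within the scatter), none beyond the scatter. Compound 3 is therefore estimated at 90% in this assay, with a range from 80% to 98%.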

Compound 3, largest response reached (reported as maximum), in percent of the reference or control that the assay uses: 98%
The estimate for compound 3 lay 8 percentage points below the measured number; the range from low to high includes it.
By their numbers in this assay, from the lowest: compounds 1, 2 and 3 (each within the scatter of the next).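

Within the data shown here, on the aromatic carbon para to a methylsulfonyl group, the only step read so far, methyl in place of chloro, is a number 7 percentage points higher from compound 2 to compound 3 (within the scatter) in this assay. At this position, then, the maximal response holds with either group, and methyl shows no loss relative to chloro. No data on these compounds bear on why the two groups read alike.

Going by these compounds, whether the response also holds with an amine, a carboxylic acid or a longer chain such as propyl on this carbon remains open.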